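A few compounds are considered here, and "the series" means these few. Any claim that something is new, unique, unknown or untested is made for them only; others in the source may bear on it.

Measured so far:
- Compound 1, `Cc1nc(S(C)(=O)=O)ccc1Oc1ncnc(OC2CCN(C(=O)SC(C)(C)C)CC2)c1F`: in a functional assay on isolated protein for inhibition of Glucose-dependent insulinotropic receptor (Rattus norvegicus), read by HTRF and cAMP accumulation (on this read-out higher numbers stand for an effect only at larger amounts of compound and lower numbers for an effect already at smaller amounts), compound 1 gives 30.7 nM.
- Compound 2, `Cc1nc(S(C)(=O)=O)ccc1Oc1ncnc(OC2CCN(C(=S)OC3(C)CC3)CC2)c1F`: in this assay compound 2 gives 48.8 nM.

Only these two numbers exist, and compound 2 sits at one end of them. Its nearest neighbour is compound 1, and the step of a 1.6-fold higher number from compound 1 to compound 2 (0.20 log units; within the scatter) lies within the scatter, so the two compounds cannot be told apart on this read-out.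

Compound 3, `Cc1nc(S(C)(=O)=O)ccc1Oc1ncnc(OC2CCN(C(=O)C(C)(F)F)CC2)c1F`, has not yet been measured. It differs from compound 2 by a group of 6 heavy atoms (3 carbon, 1 oxygen, 2 fluorine; no ring) in place of a group of 7 heavy atoms (5 carbon, 1 oxygen, 1 sulfur; one three-membered non-aromatic ring of carbon only), on an amine nitrogen in a ring; the group that leaves carries one three-membered non-aromatic ring, the (1,1-difluoroethyl)carbonyl that enters has no ring, and the place is an amine nitrogen in a ring of a six-membered non-aromatic ring with 1 nitrogen.

For the measured compounds named here, the only step that bears on this change is the swap at the same nitrogen, a 1.6-fold higher number from compound 1 to compound 2 (0.20 log units; within the scatter), which stayed within the scatter. On that basis the expected step of a 1.2-fold lower number from compound 2 to compound 3 (0.09 log units; within the scatter) is small, in no clear direction. Compound 3 is therefore estimated at 40 nM in this assay, with a range from 15 nM to 110 nM.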

Compound 3, half-maximal effective concentration: 239 nM
Estimate against measurement, compound 3: 6.0-fold (0.78 log units) below, outside the stated range (above it).
By their numbers in this assay, from the lowest: compounds 1 and 2 (each within the scatter of the next); then compound 3.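

The amine nitrogen in the six-membered non-aromatic ring is not indifferent to what it carries: in this assay, putting the (1,1-difluoroethyl)carbonyl there gives a 4.9-fold higher number from compound 2 to compound 3 (0.69 log units; beyond the scatter), so more compound is needed for the same effect. The comparison with the other sulfur-containing group, 1,1-difluoroethyl in place of (tert-butyl)sulfanyl on a carbonyl carbon, points the same way at a 7.8-fold higher number from compound 1 to compound 3 (0.89 log units; beyond the scatter), whereas the earlier swap at this nitrogen had stayed within the scatter and gave no sign that the position could respond at all. Nothing available here explains this rise in the number.

Each step changes more than one feature at once, since the sulfur leaves, fluorine enters and the group's shape differs, so the three compounds cannot show which of these matters. A plain ethyl or a tert-butyl directly on the same carbonyl, or an amine such as dimethylamino in that place, would help separate the loss of sulfur from the gain of fluorine.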